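Methyl-for-hydrogen step carried across two cores

The compounds below may be only part of what the source reports. "The series", "measured", "known", "first", "only" and "open" are said of these compounds alone.

Compound 1 `OC[C@H]1C[C@@H](Cn2cnc3c(-c4ccccc4)ncnc32)c2ccccc21` and compound 2 `Cc1ccc(-c2ncnc3c2ncn3C[C@@H]2C[C@H](CO)c3ccccc32)cc1` share one core; compound 3 `O=C(/C=C/c1cc(=O)[nH]c(=O)n1COCCO)c1ccccc1` and compound 4 `Cc1ccc(C(=O)/C=C/c2cc(=O)[nH]c(=O)n2COCCO)cc1` share another. The difference between the two cores is not broken down here. In an ADME assay on L1210/0 cells (Mus musculus) for cytotoxicity, with a stated time of 48 h (a lower number here means a stronger inhibitor, a higher number a weaker inhibitor), compound 1 gives 28100 nM, and compound 2 gives 15400 nM; compound 3 gives 43300 nM. The change from compound 1 to compound 2 is methyl in place of hydrogen on an aromatic carbon and it made a 1.8-fold lower number from compound 1 to compound 2 (0.26 log units; within the scatter). Compound 4 carries methyl in place of hydrogen on an aromatic carbon on its own core, with the place described in identical words, so the two are the same change. Compound 3 and compound 1 lie within the scatter of each other, while compound 3 and compound 2 differ by more than the scatter. Compound 4 has not yet been measured. Because a 1.8-fold lower number from compound 1 to compound 2 (0.26 log units; within the scatter) stayed within the scatter, the step in this assay is expected to be of similar size, a 1.6-fold lower number from compound 3 to compound 4 (0.21 log units; within the scatter), and this rests on that single measured pair alone. Compound 4 is accordingly estimated at 27000 nM, with a range from 12000 nM to 70000 nM.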

Compound 4, half-maximal inhibitory concentration: 27900 nM
Compound 4: middle estimate off by 1.0-fold (0.01 log units), on the low side, and the stated range covers the measured number.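

In this assay, the phenyl to 4-methylphenyl change on the core of compound 3 gives a 1.6-fold lower number from compound 3 to compound 4 (0.19 log units; within the scatter). This step matches the one on the core of compound 1, so the change carried from one core to the other with no difference that can be told from the scatter: the same change on two cores in this assay, a 1.8-fold lower number (0.26 log units; within the scatter) from compound 1 to compound 2 and a 1.6-fold lower number (0.19 log units; within the scatter) from compound 3 to compound 4, 1.2-fold (0.07 log units) apart, within the scatter of two such steps. Both steps lie within the scatter, so these two pairs show only that methyl in place of hydrogen stayed a small step on both cores; they do not show that methyl itself lowers the number, nor that the match would hold on a third core or in any other assay.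

Going by these compounds, it remains open whether a different group at this place on the six-membered aromatic ring, such as a methoxy, a chlorine or a carboxylic acid, would move the number beyond the scatter. On these data alone, it also remains open whether a step of that larger size would carry between the two cores as closely as this one did.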